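This account rests on a few compounds, and the source may have more. Where it says the series, first, only, none or still open, it means among the compounds named here.

Measured compounds in an assay on HEK293 cells for inhibition of acid ceramidase (Rattus norvegicus), read by LC-MS, with a stated time of 30 min; on this read-out lower numbers stand for stronger inhibition and higher numbers for weaker inhibition:
- compound 1, `CCCCCCNC(=O)n1cc(I)c(=O)[nH]c1=O`: 147 nM
- compound 2, `CCCCCCNC(=O)n1cc(F)c(=O)n(C)c1=O`: 13 nM

For the measured compounds named here, compound 2 gives the lower of the two numbers so far; compound 1 sits well higher, a gap beyond the scatter. Compounds 1 and 2 differ in more than one place, so no single step can be read from the pair, and it is only recorded that the two values are far apart.

The next compound in the series, compound 3, `CCCCCCNC(=O)n1cc(F)c(=O)n(CC2CC2)c1=O`, keeps everything of compound 2 except the change (cyclopropyl in place of hydrogen on a saturated chain carbon bound to an aromatic nitrogen). Going by the values given here, no measured pair in this set shows the effect of that change, so there is no step to lean on. The working expectation is a small step, within the scatter or a little towards weaker inhibition, with the full group on the aromatic nitrogen growing from methyl to cyclopropylmethyl.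

On that basis compound 3 is estimated at 22 nM, with a range from 6 nM to 90 nM. The step this estimate means is a 1.7-fold higher number from compound 2 to compound 3 (0.23 log units; within the scatter), which is expected to stay close to the scatter.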

Compound 3, half-maximal inhibitory concentration: 61 nM
Beside the measured number, compound 3's estimate is 2.8-fold (0.44 log units) below it, and the stated range covers the measured number.
By their numbers in this assay, from the lowest: compound 2; then compound 3; then compound 1.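

In this assay growing the group on the aromatic nitrogen from methyl to cyclopropylmethyl gives a 4.7-fold higher number from compound 2 to compound 3 (0.67 log units; beyond the scatter) and so moves the number towards weaker inhibition by more than the scatter. For the compounds shown here, this is the first step that can be read in one place, and it shows that the read-out responds to cyclopropyl in place of hydrogen on a saturated chain carbon bound to an aromatic nitrogen. Nothing available explains this step, so it stands as an observation on a single pair.

The compounds shown leave open whether a group such as ethyl, a longer straight chain, a benzyl group or a chain ending in an amine or a carboxylic acid on the same aromatic nitrogen would stay close to compound 2 or move further towards weaker inhibition, since one step gives no trend along the group. Also open, going by these compounds, is whether the change from methyl to cyclopropylmethyl has a step of similar size when iodine replaces fluorine on the shared core, or when the hexyl chain of the urea is replaced by another chain.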